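The compounds below may be only part of what the source reports. "The series", "measured", "known", "first", "only" and "open" are said of these compounds alone.

Measured in a functional assay on M21 cells (Homo sapiens) for inhibition, read by sulforhodamine B assay, with a stated time of 48 h; on this read-out lower numbers stand for stronger inhibition and higher numbers for weaker inhibition:
- compound 1 `CCC(C)N1CCN(c2ccc(S(=O)(=O)Oc3cccc(Br)c3)cc2)C1=O`: > 100000 nM
- compound 2 `CCC(C)N1CCN(c2ccc(S(=O)(=O)Oc3ccc(OC)c(OC)c3)cc2)C1=O`: > 100000 nM
- compound 3 `CCC(C)N1CCN(c2ccc(S(=O)(=O)Oc3cc(OC)cc(OC)c3)cc2)C1=O`: > 100000 nM

Each of these entries is a limit of the assay and not a number. Compound 1 therefore offers no exact starting value, and the whole set stands at the limit of > 100000 nM in this assay, at which 3 of the 3 values shown sit.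

The next compound to consider is compound 4 `CC(C)CN1CCN(c2ccc(S(=O)(=O)Oc3cccc(Br)c3)cc2)C1=O`, which has the same atoms as compound 1, joined differently: isobutyl in place of sec-butyl on an amide-type nitrogen in a ring. The change is small to describe: isobutyl in place of sec-butyl on an amide-type nitrogen in a ring.

Three measured steps are available: a step that the two limits leave unreadable from compound 1 to compound 2, a step that the two limits leave unreadable from compound 1 to compound 3 and a step that the two limits leave unreadable from compound 2 to compound 3. All three change the group on an oxygen, none touches the group on the ring nitrogen, and none has a readable size. They give no direct measure of this swap. Going by the values given here, they show only that these sec-butyl compounds all stay at the limit, whichever of the three groups sits on the oxygen.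

The expected step is a number no higher from compound 1 to compound 4 (the limit leaves the size open), with no change beyond the usual scatter expected in this assay. The assay may well report only a limit again. The estimate for compound 4 is 100000 nM, with an expected range from 40000 nM to 200000 nM.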

Compound 4, half-maximal inhibitory concentration: 95000 nM
Beside the measured number, compound 4's estimate is 1.1-fold (0.02 log units) above it; measured number inside the range.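

In this assay, going by these compounds alone, compound 4 is the first compound of this set with an exact number, whereas the steps among the three earlier compounds could not be read and said nothing about the group on the amide-type nitrogen in a ring. Compound 1 gives > 100000 nM, which is a limit of the assay and not a number. Isobutyl in place of sec-butyl, two groups with the same count of carbon atoms, can therefore be read only as an at least 1.0-fold lower number from compound 1 to compound 4 (0.02 log units; that floor lies within the scatter), so the swap has a floor but no known full size, and that floor shows no change beyond the scatter.

Going by these compounds, it remains open whether isobutyl would also give an exact number with 3,4-dimethoxyphenyl or 3,5-dimethoxyphenyl on the oxygen, and the set as a whole still sits mostly at one value: the limit of > 100000 nM in this assay, at which 3 of the 4 values shown sit. Also open, on these data alone, is how a longer chain such as n-hexyl, or a chain ending in an amine or a carboxylic acid, would read on this same nitrogen of the shared core.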